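The source may hold more compounds than are shown below. What is called first, only, known or untested is meant among the compounds shown, and "the series" means these compounds.

Of the compounds shown here, three built on one shared core have so far been tested in a functional assay on HCT-116 cells (Homo sapiens) for inhibition, read by MTT assay, with a stated time of 48 h; a lower number here means a stronger inhibitor, a higher number a weaker inhibitor. Compound 1, `O=C(CSc1nnc(-c2ccncc2)n1-c1ccccc1)N/N=C/c1ccc(O)cc1`, returns in this assay only a limit of the assay, > 50000 nM. Compound 2, `O=C(CSc1nnc(-c2ccncc2)n1-c1ccccc1)N/N=C/c1ccccc1F`, gives 18000 nM in this assay. Compound 3, `O=C(CSc1nnc(-c2ccncc2)n1-c1ccccc1)N/N=C/c1cc(Br)ccc1O`, gives 1990 nM in this assay, the lowest of the two numbers shown, with compound 2 as its nearest neighbour. The steps leading to compound 3 are an at least 25-fold lower number from compound 1 to compound 3 (1.40 log units; beyond the scatter) and a 9.0-fold lower number from compound 2 to compound 3 (0.96 log units; beyond the scatter), while the remaining step is an at least 2.7-fold lower number from compound 1 to compound 2 (0.44 log units; beyond the scatter). Because compound 1 sits at the limit of > 50000 nM in this assay, at which 1 of the 3 values shown sits, the size of the first of these steps is known only as a bound.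

Compound 4, `O=C(CSc1nnc(-c2ccncc2)n1-c1ccccc1)N/N=C/c1ccc(O)c(O)c1`, is not yet measured. It differs from compound 3 in one place: 3,4-dihydroxyphenyl in place of 5-bromo-2-hydroxyphenyl on a carbon with a double bond to nitrogen. The step from compound 1 to compound 3 bears most directly, since compound 4 likewise carries a hydroxyphenyl without bromine on that carbon; the step from compound 2 to compound 3 points the same way. A large rise in the number is therefore expected, though the second hydroxyl keeps compound 4 distinct from compound 1. Compound 4 is expected to give about 15000 nM in this assay, within 3000 nM to 60000 nM. This corresponds to an expected step of a 7.5-fold higher number from compound 3 to compound 4 (0.88 log units; beyond the scatter).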

Compound 4, half-maximal inhibitory concentration: 14700 nM
Beside the measured number, compound 4's estimate is 1.0-fold (0.01 log units) above it; measured number inside the range.
By their numbers in this assay, from the lowest: compound 3; then compounds 4 and 2 (each within the scatter of the next). At a limit, above all of these: compound 1.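

In this assay, the change from 5-bromo-2-hydroxyphenyl to 3,4-dihydroxyphenyl on the carbon with a double bond to nitrogen gives a 7.4-fold higher number from compound 3 to compound 4 (0.87 log units; beyond the scatter), so a ring with a second hydroxy group in place of the bromine does not keep the low number of compound 3. The step of a 1.2-fold lower number from compound 2 to compound 4 (0.09 log units; within the scatter) shows that 3,4-dihydroxyphenyl and 2-fluorophenyl read alike at this place despite their different substituents, which leaves compound 3 alone at the low end of the series. Adding hydroxy to the ring of compound 1 gives an at least 3.4-fold lower number from compound 1 to compound 4 (0.53 log units; beyond the scatter), the first sign that this single added group can move the number, though the step is only a bound, compound 1 standing at a limit of the assay: the limit of > 50000 nM in this assay, at which 1 of the 4 values shown sits.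

The compounds shown do not separate the part played by the bromine in 5-bromo-2-hydroxyphenyl from that of its hydroxy group, as no ring here carries one without the other in that arrangement. As far as these compounds go, how an amine or a carboxylic acid on this ring would read also remains open.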